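Benzyl Ester in Place of tert-Butyl: Solubility Outlook

A few compounds are considered here, and "the series" means these few. Any claim that something is new, unique, unknown or untested is made for them only; others in the source may bear on it.

Of the compounds shown here, two have been measured in a physicochemical assay for solubility, read by nephelometry, in phosphate buffer, measured as kinetic solubility, at pH 6.5; on this read-out lower numbers stand for lower solubility and higher numbers for higher solubility. Compound 1 `CCOC(=O)C1=C(C)N/C(=C/c2cc(C)n(-c3ccncc3)c2C)C1=O` gives 50 ug/mL in this assay. Compound 2 `CC1=C(C(=O)OC(C)(C)C)C(=O)/C(=C\c2cc(C)n(-c3ccccc3C(F)(F)F)c2C)N1` gives 1.6 ug/mL in this assay, the lower of the two numbers, and its gap to compound 1 lies beyond the scatter. Compound 3 `CC1=C(C(=O)OCc2ccccc2)C(=O)/C(=C\c2cc(C)n(-c3ccccc3C(F)(F)F)c2C)N1` differs from compound 2 in one place: benzyl in place of tert-butyl on an oxygen next to a carbonyl group. Going by the values given here, no step between measured compounds covers this change, so the expectation rests on compound 2 alone. The step of a 1.3-fold lower number from compound 2 to compound 3 (0.12 log units; within the scatter) is expected to be small, not beyond the scatter. Compound 3 is estimated at 1.2 ug/mL, within a range from 0.4 ug/mL to 4 ug/mL.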

Compound 3, solubility: < 1.6 ug/mL
Compound 3: only a limit was reported (the forecaster's own chance of this, stated with the estimate: 25%); the middle value is on the limit's open side.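

In this assay compound 3 gives < 1.6 ug/mL, which is a limit of the assay and not a number. On an oxygen next to a carbonyl group, benzyl in place of tert-butyl therefore brings a number no higher from compound 2 to compound 3 (the limit leaves the size open) and the size of the step cannot be read: the limit of < 1.6 ug/mL in this assay, at which 1 of the 3 values shown sits.

The compounds shown leave open how far compound 3 really lies past its limit. They also leave open what a chain ending in an amine, or a carboxylic acid in place of the ester, would give at this position.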